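This account rests on a few compounds, and the source may have more. Where it says the series, first, only, none or still open, it means among the compounds named here.

In an ADME assay on HEK-293T cells (Homo sapiens) for cytotoxicity, read by luminescence, with a stated time of 24 h (on this read-out lower numbers stand for higher toxicity in this test and higher numbers for lower toxicity in this test), compound 1 (`COc1ccc(Cn2c(C(=O)N3CCCCC3)cc3sccc32)cc1`) reads > 100000 nM, which is a limit. Compound 2 (`COc1ccc(Cn2c(C(=O)N3CCC(C(=O)NC(C)c4ccccc4)CC3)cc3sccc32)cc1`) reads > 100000 nM, also a limit. Within the data shown here, compound 3 (`CCCNC(=O)C1CCN(C(=O)c2cc3sccc3n2Cc2ccc(OC)cc2)CC1`) gives 18800 nM, the only value here that is not a limit, and the steps reaching it are an at least 5.3-fold lower number from compound 1 to compound 3 (0.72 log units; beyond the scatter) and an at least 5.3-fold lower number from compound 2 to compound 3 (0.72 log units; beyond the scatter).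

Compound 4 (`CCCNCc1cc2c(cc(C(=O)N3CCC(C(=O)NCCC)CC3)n2Cc2ccc(OC)cc2)s1`) carries (propylamino)methyl in place of hydrogen on an aromatic carbon, next to the ring sulfur. The change is (propylamino)methyl in place of hydrogen on an aromatic carbon.

Among the measured compounds shown here, no measured step alters the shared core. The nearest guide is the addition of propylcarbamoyl in an at least 5.3-fold lower number from compound 1 to compound 3 (0.72 log units; beyond the scatter), whereas a step that the two limits leave unreadable from compound 1 to compound 2 gives no readable size. A modest move to a lower number is therefore expected in this assay, with a 2.4-fold lower number from compound 3 to compound 4 (0.37 log units; beyond the scatter) as the expected step. Compound 4 is estimated at 8000 nM, with an expected range of 2500 nM to 30000 nM.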

Compound 4, half-maximal cytotoxic concentration: > 100000 nM
Compound 4 gave a limit, no number; the forecaster's own chance of this, stated with the estimate: 8%; middle value at least 12-fold (1.09 log units) from the limit.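

Among these compounds, the aromatic carbon next to the ring sulfur is the first position on the shared core with a measured change in this assay, and (propylamino)methyl there gives an at least 5.3-fold higher number from compound 3 to compound 4 (0.72 log units; beyond the scatter). This runs opposite to the earlier propylcarbamoyl addition, an at least 5.3-fold lower number from compound 1 to compound 3 (0.72 log units; beyond the scatter). Compound 4 gives a limit, not a number, so this step has no readable upper size: the limit of > 100000 nM in this assay, at which 3 of the 4 values shown sit.

Open, from the compounds shown here alone, is how a carboxylic acid or a plain aminomethyl group at this aromatic carbon would read. Also open, going by these compounds, is whether a longer chain on the amine would keep compound 4's reading.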